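Swapping a Fluorinated Chain End for Methoxy

The compounds below may be only part of what the source reports. "The series", "measured", "known", "first", "only" and "open" are said of these compounds alone.

Results so far in a physicochemical assay for solubility, in phosphate buffer, measured as kinetic solubility, at pH 7.4, tested at 250 uM (a higher number here means a more soluble compound, a lower number a less soluble compound), are these:
Compound 1 `CCCCCCNc1ccc(C(=O)O)cc1S(=O)(=O)N(C)C` gives 243000 nM
Compound 2 `CN(C)S(=O)(=O)c1cc(C(=O)O)ccc1NCCC(C)(C)C` gives > 250000 nM
Compound 3 `CN(C)S(=O)(=O)c1cc(C(=O)O)ccc1NCCCC(F)(F)F` gives 245000 nM

The entry for compound 2 is a limit of the assay and not a number. It stands at the limit of > 250000 nM in this assay, at which 1 of the 3 values shown sits, and gives no exact reading. The two true numbers, from compound 1 and compound 3, lie within the scatter of each other, so neither can be ranked above the other.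

The next step leads to compound 4 `COCCNc1ccc(C(=O)O)cc1S(=O)(=O)N(C)C` and the change is methoxy in place of 2,2,2-trifluoroethyl on a saturated chain carbon, two bonds along the chain from a nitrogen on an aromatic ring. Three measured steps alter the same chain (an at least 1.0-fold higher number from compound 1 to compound 2 (0.01 log units; that floor lies within the scatter)) and (a 1.0-fold higher number from compound 1 to compound 3 (0.00 log units; within the scatter)) and (an at least 1.0-fold lower number from compound 2 to compound 3 (0.00 log units; that floor lies within the scatter)) and none is shown beyond the scatter. Going by the values given here, no measured compound carries methoxy, so this evidence is indirect. With those three steps as the guide, the expectation in this assay is no step beyond the scatter, in either direction. The expected step is small (no change at the digits printed from compound 3 to compound 4 (within the scatter)) and the reading may also come back as a limit. Compound 4 is expected at 245000 nM (estimated range 190000 nM to 250000 nM).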

Compound 4, solubility: 237000 nM
Compound 4: middle estimate off by 1.0-fold (0.01 log units), on the high side; the measured number falls inside the stated range.
By their numbers in this assay, from the lowest: compounds 4, 1 and 3 (each within the scatter of the next). At a limit, above all of these: compound 2.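

Compound 4 brings the first chain end with an oxygen, and in this assay replacing either a fluorinated or an all-carbon chain end with methoxy stays within the scatter: a 1.0-fold lower number from compound 3 to compound 4 (0.01 log units; within the scatter), and a 1.0-fold lower number from compound 1 to compound 4 (0.01 log units; within the scatter). Methoxy, with 2 heavy atoms and 1 hydrogen-bond acceptor, thus takes the place of 2,2,2-trifluoroethyl, with 5 heavy atoms and 0 hydrogen-bond acceptors, and the two readings cannot be ranked, while the comparison with tert-butyl gives only a floor, an at least 1.0-fold lower number from compound 2 to compound 4 (0.02 log units; that floor lies within the scatter). Compound 2 is a limit and not a number: the limit of > 250000 nM in this assay, at which 1 of the 4 values shown sits.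

All the chain ends shown so far, alkyl, fluorinated or methoxy, leave every step within the scatter, so nothing here shows which change at this position, if any, could move the reading beyond it. Going by these compounds, whether a chain ending in an amine or a carboxylic acid, or one ending in a ring such as phenyl, would give a step beyond the scatter in this assay stays open.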